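Diethylamino extension of the tolyl arm in compound 2

The compounds below may be only part of what the source reports. "The series", "measured", "known", "first", "only" and "open" are said of these compounds alone.

Measured compounds in a functional assay on U-87MG ATCC cells (Homo sapiens) for cytotoxicity, read by MTT assay, with a stated time of 72 h; a lower number here means a stronger inhibitor, a higher number a weaker inhibitor:
compound 1, `COc1ncc(-c2ccc3nccc(N4CCCC4)c3c2)cc1NS(=O)(=O)c1ccc(F)cc1F`: 6690 nM
compound 2, `COc1ncc(-c2ccc3nccc(-c4ccc(C)cc4)c3c2)cc1NS(=O)(=O)c1ccc(F)cc1F`: 67100 nM

Going by the values given here, of the two measured compounds, compound 2 stands at the higher number in this assay, and the only measured step, a 10-fold higher number from compound 1 to compound 2 (1.00 log units; beyond the scatter), leads to it. That step exchanged the entire group on the aromatic carbon of the shared core for a 4-methylphenyl, so it describes a change of a different kind from the one considered next.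

Compound 3, `CCN(CC)Cc1ccc(-c2ccnc3ccc(-c4cnc(OC)c(NS(=O)(=O)c5ccc(F)cc5F)c4)cc23)cc1`, keeps the 4-methylphenyl of compound 2 and differs from it only by diethylamino in place of hydrogen on a saturated chain carbon bound to an aromatic carbon. Among the compounds with values here, no measured step touches this part of the molecule: the step of a 10-fold higher number from compound 1 to compound 2 (1.00 log units; beyond the scatter) replaced the whole arm rather than extending it, so it gives no measure of what the added diethylamino contributes. Within the data shown here, with no precedent of this kind among the two measured compounds, no step beyond the scatter is expected in this assay in either direction. Compound 3 is therefore estimated at 45000 nM, with a range from 12000 nM to 170000 nM. The expected step of a 1.5-fold lower number from compound 2 to compound 3 (0.17 log units; within the scatter) is accordingly estimated to remain within the scatter.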

Compound 3, half-maximal inhibitory concentration: 4890 nM
Compound 3: the middle estimate sits 9.2-fold (0.96 log units) above what was measured; measured number below the stated range.
By their numbers in this assay, from the lowest: compounds 3 and 1 (each within the scatter of the next); then compound 2.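

Adding diethylamino to the saturated chain carbon bound to an aromatic carbon in compound 2 gives a 14-fold lower number from compound 2 to compound 3 (1.14 log units; beyond the scatter) in this assay, so this small extension of the tolyl arm changes the read-out by about as much as the earlier exchange of the entire group did. Going by these compounds alone, the earlier step could show only that swapping the whole group mattered, whereas this one shows that the outer end of the 4-methylphenyl arm is itself a place where a single substitution counts. Set against the pyrrolidin-1-yl of compound 1, the 4-((diethylamino)methyl)phenyl arm gives a 1.4-fold lower number from compound 1 to compound 3 (0.14 log units; within the scatter), so the two groups cannot be told apart here, and nothing available explains either step.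

The compounds shown leave open whether the gain rests on the amine nitrogen or on the added carbons, a question that a hydroxyl, a dimethylamino or a morpholine on the same carbon would help to settle. They also leave open whether a longer chain carrying the diethylamino would keep the number of compound 3 or move it further.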